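Fluorophenyl for pyridyl on a triazole-linked diterpenoid scaffold

A few compounds are considered here, and "the series" means these few. Any claim that something is new, unique, unknown or untested is made for them only; others in the source may bear on it.

Measured compounds:
compound 1 `Cc1c(O)ccc2c1[C@H](Cn1cc(-c3ccc(F)cc3)nn1)[C@@]13CC(=O)[C@@](C)(CC[C@@H]21)C3` — > 20000 nM
compound 2 `C=C1C(=O)[C@]23C[C@@]1(O)CC[C@H]2c1ccc(O)c(C)c1[C@@H]3Cn1cc(-c2ccccn2)nn1` — 1270 nM
compound 3 `Cc1c(O)ccc2c1[C@H](Cn1cc(-c3ccccn3)nn1)[C@@]13CC(=O)[C@@](C)(CC[C@@H]21)C3` — > 20000 nM

Of the compounds shown here, three have been tested in a functional assay on SMMC-7721 cells (Homo sapiens) for cytotoxicity, read by MTT assay, with a stated time of 4 days; a lower number here means a stronger inhibitor, a higher number a weaker inhibitor. Compound 1 `Cc1c(O)ccc2c1[C@H](Cn1cc(-c3ccc(F)cc3)nn1)[C@@]13CC(=O)[C@@](C)(CC[C@@H]21)C3` gives only a limit, > 20000 nM. Compound 3 `Cc1c(O)ccc2c1[C@H](Cn1cc(-c3ccccn3)nn1)[C@@]13CC(=O)[C@@](C)(CC[C@@H]21)C3` likewise gives only a limit, > 20000 nM. Among the measured compounds shown here, compound 2 `C=C1C(=O)[C@]23C[C@@]1(O)CC[C@H]2c1ccc(O)c(C)c1[C@@H]3Cn1cc(-c2ccccn2)nn1` is the one compound with a number, 1270 nM in this assay. For the measured compounds named here, compound 2 and compound 3 differ by a large part of the molecule, and the difference between the two cores is not broken down here; their two values show only that compound 2 has a number where compound 3 has a limit.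

The change from compound 3 to compound 1 is 4-fluorophenyl in place of pyridin-2-yl on an aromatic carbon, and its step in this assay is a step that the two limits leave unreadable from compound 3 to compound 1. The same change, (4-fluorophenyl in place of pyridin-2-yl on an aromatic carbon), carries compound 2 to compound 4 `C=C1C(=O)[C@]23C[C@@]1(O)CC[C@H]2c1ccc(O)c(C)c1[C@@H]3Cn1cc(-c2ccc(F)cc2)nn1`, which has not been measured in this assay. Since both compound 1 and compound 3 sit at the limit of > 20000 nM in this assay, at which 2 of the 3 values shown sit, the measured pair says nothing about the direction or size of this change on a core where a number is seen.

With no readable precedent, compound 4 is expected to stay near compound 2, which gave 1270 nM, so the estimated step from compound 2 to compound 4 is a 1.2-fold higher number from compound 2 to compound 4 (0.07 log units; within the scatter). For compound 4 the expected value in this assay is 1500 nM, estimated to lie between 500 nM and 6000 nM.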

Compound 4, half-maximal inhibitory concentration: 850 nM
Beside the measured number, compound 4's estimate is 1.8-fold (0.25 log units) above it; the measured number falls inside the stated range.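

In this assay, on the core where a number can be read, 4-fluorophenyl in place of pyridin-2-yl gives a 1.5-fold lower number from compound 2 to compound 4 (0.17 log units; within the scatter), so on this core the two groups cannot be told apart in this read-out. On the other core the same change cannot be read, since compound 1 and compound 3 each give only a limit and not a number: the limit of > 20000 nM in this assay, at which 2 of the 4 values shown sit. This leaves a single readable instance of the change, on a single core, so the result does not show that the change behaves alike on both cores, and it does not show what either group would give on the other core if a number could be read there.

The compounds shown vary the group on the five-membered aromatic ring with 3 nitrogen only between these two six-membered aromatic rings, so it remains open how an aminomethyl group, a carboxylic acid or a longer alkyl chain in that place would read on the core of compound 2. Also open is which part of the difference between the two cores separates the compounds with a limit from those with a number, as no compound shown divides that difference into single changes.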